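From Dimethylamino to Pyrrolidinyl on a Shared Core

The compounds below may be only part of what the source reports. "The series", "measured", "known", "first", "only" and "open" are said of these compounds alone.

Compound 1 `CCON/C(=N\C1=NC(=O)C(=O)N1C(C)C)Nc1ccc(Cl)c(Cl)c1`: in an in vitro ADME assay on microsomes from liver (Mus musculus) for metabolic stability, read by LC-MS (a lower number here means that the compound disappears faster, a higher number that the compound lasts longer), compound 1 gives > 1 h, which is a limit of the assay rather than a number.
Compound 2 `CC(C)N1C(=O)C(=O)N=C1/N=C(\NCCN(C)C)Nc1ccc(Cl)c(Cl)c1`: in this assay compound 2 gives > 1 h, again a limit of the assay.

Compound 2 therefore stands at the limit, with nothing above it to compare against. For the measured compounds named here, the only measured step, a step that the two limits leave unreadable from compound 1 to compound 2, cannot be sized because of the limit of > 1 h in this assay, at which 2 of the 2 values shown sit. Compound 3 `CC(C)N1C(=O)C(=O)N=C1/N=C(\NCCN1CCCC1)Nc1ccc(Cl)c(Cl)c1` differs from compound 2 by pyrrolidin-1-yl in place of dimethylamino on a saturated chain carbon, two bonds along the chain from an amine nitrogen. Going by the values given here, no measured step bears on this change, since the one step known is unreadable. With both measured values at the limit, the expectation for compound 3 rests only on compound 2 sitting at > 1 h. Compound 3 is therefore expected to show no step beyond the scatter, a step that the limit leaves unreadable from compound 2 to compound 3, and most likely to reach the limit again. The estimated value for compound 3 is 1.5 h, within 0.6 h to 4 h.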

Compound 3, half-life: > 1 h
Compound 3: only a limit was reported; the forecaster's own chance of this, stated with the estimate: 70%; the middle value lies beyond the limit too.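

In this assay compound 3 gives > 1 h, which is a limit of the assay and not a number. The steps among compound 1, compound 2 and compound 3 cannot be read, because all three stop at the same point: the limit of > 1 h in this assay, at which 3 of the 3 values shown sit. From the compounds shown here alone, how long each compound actually lasts, and whether pyrrolidin-1-yl and dimethylamino differ at all here, stays open.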